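A few compounds are considered here, and "the series" means these few. Any claim that something is new, unique, unknown or untested is made for them only; others in the source may bear on it.

Measured in a functional assay on CAL-51 cells (Homo sapiens) for inhibition, read by sulforhodamine B assay, with a stated time of 3 days; on this read-out higher numbers stand for weaker inhibition of growth and lower numbers for stronger inhibition of growth:
Compound 1 `O=C(/C=C/c1ccccc1Cl)c1ccc(OCc2ccccc2)cc1`: 7100 nM
Compound 2 `O=C(/C=C/c1ccc(OCc2ccccc2)cc1)c1ccccc1`: 24700 nM
Compound 3 `Cc1ccc(COc2ccc(C(=O)/C=C/c3ccc(F)cc3)cc2)cc1`: > 50000 nM, a limit of the assay

Of the two actual numbers, compound 2 has the higher, and compound 1 lies lower by more than the usual scatter. Compound 4 `O=C(/C=C/c1ccc(F)cc1)c1ccccc1` comes from compound 2 by one change: fluoro in place of benzyloxy on an aromatic carbon. Going by the values given here, no measured pair shows this change directly. Compound 3, which also carries a fluoro group, gives only a limit, > 50000 nM. The starting point for the expectation is therefore compound 2 at 24700 nM. The expected step of a 1.1-fold higher number from compound 2 to compound 4 (0.05 log units; within the scatter) is none beyond the scatter, with at most a slight drift towards weaker inhibition. Compound 4 is estimated at 28000 nM, with an expected range from 10000 nM to 50000 nM.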

Compound 4, concentration for 50% growth inhibition: 2780 nM
Beside the measured number, compound 4's estimate is 10-fold (1.00 log units) above it, and the stated range ends above it.
By their numbers in this assay, from the lowest: compound 4; then compound 1; then compound 2. At a limit, above all of these: compound 3.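

Replacing benzyloxy with fluoro in this assay gives an 8.9-fold lower number from compound 2 to compound 4 (0.95 log units; beyond the scatter) and so shows that this aromatic carbon does not need the large benzyloxy group, with its extra ring, for inhibition of growth. A single fluorine atom there does better. Nothing measured here explains why.

Going by these compounds, it stays open whether losing benzyloxy or gaining fluoro drives the step. A plain hydrogen, a methoxy group or an amine at this carbon would help to separate the two.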